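The compounds below may be only part of what the source reports. "The series", "measured", "known", "first", "only" and "open" are said of these compounds alone.

Measured so far:
compound 1 `CN1[C@@H]2c3[nH]c4ccccc4c3C[C@H]1[C@H](C#N)N1[C@@H](CNC(=O)c3ccc(Cl)cc3)c3[nH]c4ccccc4c3C[C@@H]21`: 110 nM
compound 2 `CN1[C@@H]2c3[nH]c4ccccc4c3C[C@H]1[C@H](C#N)N1[C@@H](CNC(=O)c3cc4ccccc4s3)c3[nH]c4ccccc4c3C[C@@H]21`: 240 nM

In a functional assay on BGC-823 cells (Homo sapiens) for cytotoxicity, read by MTT assay, with a stated time of 72 h (on this read-out lower numbers stand for stronger inhibition and higher numbers for weaker inhibition), compound 2 gives 240 nM, the highest of the two numbers, while compound 1 gives 110 nM. For the measured compounds named here, the one measured step reads a 2.2-fold higher number from compound 1 to compound 2 (0.34 log units; beyond the scatter), a modest rise. Compound 3 `CN1[C@@H]2c3[nH]c4ccccc4c3C[C@H]1[C@H](C#N)N1[C@@H](CNC(=O)c3cc4ccccc4[nH]3)c3[nH]c4ccccc4c3C[C@@H]21` differs from compound 2 by 1H-indol-2-yl in place of 1-benzothiophen-2-yl on a carbonyl carbon. No measured pair swaps these two groups, so nothing shown speaks directly to this change. Going by the values given here, the single step, a 2.2-fold higher number from compound 1 to compound 2 (0.34 log units; beyond the scatter), concerns a different exchange at the same carbonyl and shows only that replacing one aromatic group by another on this carbonyl has moved the read-out by a modest amount. For compound 3 the expected step is therefore small, a 1.2-fold lower number from compound 2 to compound 3 (0.08 log units; within the scatter), with no confident direction. The estimate for compound 3 in this assay is 200 nM, expected to lie between 70 nM and 600 nM.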

Compound 3, half-maximal inhibitory concentration: 1690 nM
Estimate against measurement, compound 3: 8.5-fold (0.93 log units) below, outside the stated range (above it).
By their numbers in this assay, from the lowest: compound 1; then compound 2; then compound 3.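

In this assay, the read-out at this carbonyl proved far more sensitive than the earlier step suggested. 1H-indol-2-yl in place of 1-benzothiophen-2-yl gives a 7.0-fold higher number from compound 2 to compound 3 (0.85 log units; beyond the scatter), although both groups have the same ring types and heavy-atom count and differ only in the hetero atom and in their hydrogen-bond donor and acceptor counts. Set against 4-chlorophenyl, the same group gives a 15-fold higher number from compound 1 to compound 3 (1.19 log units; beyond the scatter), so aromatic exchanges at this carbonyl are not all modest, and no measurement shown accounts for the rise.

The compounds shown leave open how 1-methyl-1H-indol-2-yl, which keeps the indole rings but replaces the ring hydrogen on nitrogen with methyl, would compare with compound 3. They also leave open where 1-benzofuran-2-yl, with oxygen as its hetero atom, would fall in this order.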